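Shrinking the Amide Ring: From Cyclopentyl to Cyclopropyl

This account rests on a few compounds, and the source may have more. Where it says the series, first, only, none or still open, it means among the compounds named here.

Three analogues sharing one core have been run in a functional assay on HCT-116 cells (Homo sapiens) for antiproliferative activity, read by MTT assay, with a stated time of 72 h; on this read-out lower numbers stand for stronger inhibition and higher numbers for weaker inhibition. Compound 1 `Cn1cc(-c2nn(Cc3ccc(C(=O)N4CCCCC4)cc3)c(=O)c3ccccc23)cn1` gives 73900 nM. Compound 3 `Cn1cc(-c2nn(Cc3ccc(C(=O)NC4CCCC4)cc3)c(=O)c3ccccc23)cn1` gives 14300 nM, the lowest of the two numbers shown, and the step of a 5.2-fold lower number from compound 1 to compound 3 (0.71 log units; beyond the scatter) is the only measured change at this position. Compound 2 `Cc1noc(C)c1-c1nn(Cc2ccc(C(=O)NC3CC3)cc2)c(=O)c2ccccc12`, which carries a different heteroaryl group on the core, returns only the assay limit > 100000 nM; this is a limit of > 100000 nM in this assay, at which 1 of the 3 values shown sits, and not a number.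

The next compound, compound 4 `Cn1cc(-c2nn(Cc3ccc(C(=O)NC4CC4)cc3)c(=O)c3ccccc23)cn1`, keeps the core of compound 3 and changes the amide substituent: cyclopropyl in place of cyclopentyl on an amide-type nitrogen. The step from compound 1 to compound 3 shows that a smaller ring on this amide can lower the number, yet the only cyclopropylamide measured, compound 2, sits at the limit and has a different heteroaryl group, so it does not settle the question. The author therefore expects for compound 4 a step of a 2.1-fold higher number from compound 3 to compound 4 (0.32 log units; beyond the scatter) of modest size toward weaker inhibition, and estimates 30000 nM for compound 4, within a range from 10000 nM to 100000 nM.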

Compound 4, half-maximal inhibitory concentration: 20100 nM
Compound 4: the middle estimate sits 1.5-fold (0.17 log units) above what was measured; low and high end bracket the measured number.
By their numbers in this assay, from the lowest: compounds 3 and 4 (each within the scatter of the next); then compound 1. At a limit, above all of these: compound 2.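

In this assay, the step of a 1.4-fold higher number from compound 3 to compound 4 (0.15 log units; within the scatter) shows that cyclopentyl and cyclopropyl on this amide-type nitrogen cannot be told apart, while a 3.7-fold lower number from compound 1 to compound 4 (0.57 log units; beyond the scatter) shows that the change away from piperidin-1-yl also holds with a second ring, not only with cyclopentylamino. Among the compounds shown here, with the cyclopropyl amide now held constant, the change at the heteroaryl group can be read for the first time, as an at least 4.9-fold lower number from compound 2 to compound 4 (0.69 log units; beyond the scatter). That step has only a lower bound, since the value for compound 2 is a limit and not a number: the limit of > 100000 nM in this assay, at which 1 of the 4 values shown sits.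

On these data alone, whether an open chain such as n-butyl, or a ring carrying an amine or a carboxylic acid, would move the number on this amide-type nitrogen stays open. As far as these compounds go, how large the heteroaryl step really is also remains unknown.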